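The source may report more compounds than this note shows. Statements on the series, on what has been measured and on what is new or still open speak of the compounds shown alone.

Values so far in an ADME assay on a cell-free system (plasma, Homo sapiens) for protein binding, read by LC-MS, with a stated time of 5 h, tested at 10 uM, for the series
Compound 1 `COc1ccc2c(ccn2-c2ccc(O[C@H]3O[C@H](CO)[C@@H](O)[C@H](O)[C@@H]3O)c(Cl)c2)c1` gives 96%
Compound 2 `CS(=O)(=O)Nc1ccc2c(ccn2-c2ccc(O[C@H]3O[C@H](CO)[C@@H](O)[C@H](O)[C@@H]3O)c(Cl)c2)c1` gives 94%
Compound 3 `OC[C@H]1O[C@H](Oc2ccc(-n3ccc4cc(Cl)cnc43)cc2Cl)[C@@H](O)[C@@H](O)[C@@H]1O` gives 96%

Compound 3 reads the same as compound 1 at the digits given, and compound 2 lies within the scatter of both, so the three values do not separate. Compound 4 `N#Cc1cnc2c(ccn2-c2ccc(O[C@H]3O[C@H](CO)[C@@H](O)[C@H](O)[C@@H]3O)c(Cl)c2)c1` is still to be measured in this assay and is the next point. The change from compound 3 to compound 4 is cyano in place of chloro on an aromatic carbon of a six-membered aromatic ring with 1 nitrogen, two atoms from the ring nitrogen (cyano in place of chloro on an aromatic carbon).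

For the measured compounds named here, no measured step covers this exchange. Going by the values given here, the one step available is a 1.5-fold higher unbound fraction from compound 1 to compound 2 (0.18 log units; within the scatter) and it concerns a different exchange, methanesulfonamido in place of methoxy, so it is only a weak guide. It stayed within the scatter. No step beyond the scatter is therefore expected in this assay for the new compound, with a slight lean toward more free compound left open. The expected step is a 1.5-fold higher unbound fraction from compound 3 to compound 4 (0.18 log units; within the scatter) and it is estimated to remain within the scatter. For compound 4 the estimated value is 94% with an expected range from 88% to 97% as the working figures.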

Compound 4, plasma protein binding in the plasma assay: 95%
Compound 4: middle estimate off by 1.2-fold (0.08 log units) (unbound fraction), on the high side; low and high end bracket the measured number.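

On an aromatic carbon of the six-membered aromatic ring with 1 nitrogen, two atoms from the ring nitrogen, cyano in place of chloro gives in the plasma assay a 1.3-fold higher unbound fraction from compound 3 to compound 4 (0.10 log units; within the scatter) and so leaves the two compounds unresolved, as did the earlier exchange with a 1.5-fold higher unbound fraction from compound 1 to compound 2 (0.18 log units; within the scatter) at another place on the core. New here is that a physicochemical assay for lipophilicity, using the shake flask method, in phosphate buffer, measured as octanol-water partition, with a stated time of 2 h, at pH 7.4, tested at 1 uM (a lower number here means a more polar compound, a higher number a more lipophilic compound), does respond to the exchange: compound 3 gives 3.4 and compound 4 gives 1.6. In the physicochemical assay a number 1.80 log units lower from compound 3 to compound 4 (beyond the scatter) is the size of the move. At this position lipophilicity and plasma binding therefore part, a large drop in the distribution coefficient coming with no readable shift in the unbound fraction, as the physicochemical assay shows: the measured distribution coefficient of compound 3, 3.4, and of compound 4, 1.6, a number 1.80 log units lower (beyond the scatter).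

On these data alone, all of this rests on a single pair, so how much further the distribution coefficient can move before the unbound fraction follows remains open. Also open, as far as these compounds go, is what a carboxylic acid or a primary amine on the same aromatic carbon would do to either read-out.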